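The source may hold more compounds than are shown below. What is called first, only, known or untested is meant among the compounds shown, and "the series" means these compounds.

Of the compounds shown here, two have been tested in a functional assay on U-87MG ATCC cells for antiproliferative activity against U-87 MG (Homo sapiens), read by MTT assay, with a stated time of 72 h; a lower number here means a stronger inhibitor, a higher number a weaker inhibitor. Compound 1 `O=C(Nc1ccc(Oc2ccnc3[nH]ccc23)c(F)c1)c1cc2cccnc2n(-c2ccc(F)cc2)c1=O` gives 620 nM, and compound 2 `O=C(Nc1ccc(Oc2ccnc3[nH]ccc23)c(F)c1)c1cc2cccnc2n(-c2ccc(Br)cc2)c1=O` gives 1510 nM. On these two numbers compound 2 stands highest, that is, as the weaker inhibitor; its nearest neighbour is compound 1, and the change was a 2.4-fold higher number from compound 1 to compound 2 (0.39 log units; beyond the scatter), which came with bromo in place of fluoro on an aromatic carbon.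

Compound 3 `O=C(Nc1ccc(Oc2ccnc3[nH]ccc23)c(F)c1)c1cc2cccnc2n(-c2ccc(F)c(Cl)c2)c1=O` has not yet been measured. It differs from compound 2 by 3-chloro-4-fluorophenyl in place of 4-bromophenyl on an aromatic nitrogen. In effect this puts fluoro back at the position where compound 1 carried it, and adds a chloro that neither compound 1 nor compound 2 has.

Going by the values given here, the only measured step that bears on this is the one from compound 1 to compound 2, which was modest. Undoing it should pull the number back toward compound 1, while the added chloro has no comparison in the data. The expectation for compound 3 is therefore a number between compound 1 and compound 2, with a step of a 1.9-fold lower number from compound 2 to compound 3 (0.28 log units; within the scatter) from compound 2, so compound 3 is estimated at 800 nM, within a range of 300 nM to 2500 nM.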

Compound 3, half-maximal inhibitory concentration: 5230 nM
Estimate against measurement, compound 3: 6.5-fold (0.82 log units) below; the measured number lies above the stated range.
By their numbers in this assay, from the lowest: compound 1; then compound 2; then compound 3.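

The cleanest comparison is the one that only adds chloro in place of hydrogen on an aromatic carbon of the phenyl group on the aromatic nitrogen, and in this assay it gives an 8.4-fold higher number from compound 1 to compound 3 (0.93 log units; beyond the scatter), a larger step than the bromo-for-fluoro swap, which gave a 2.4-fold higher number from compound 1 to compound 2 (0.39 log units; beyond the scatter). Replacing 4-bromophenyl with 3-chloro-4-fluorophenyl gives a 3.5-fold higher number from compound 2 to compound 3 (0.54 log units; beyond the scatter), so the return of fluoro does not bring the number back toward that of compound 1, and the added chloro goes with a weaker inhibitor, showing that this group does not simply tolerate an extra halogen. Nothing available explains why this chloro weakens the compound.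

From the compounds shown here alone, what remains open is whether the penalty belongs to chloro itself or would also appear with another group on that carbon, such as methyl or methoxy. It is also unclear how a plain phenyl group with no halogen would compare, so these three compounds fix neither a best group at this position nor a trend beyond themselves.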